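A few compounds are considered here, and "the series" means these few. Any claim that something is new, unique, unknown or untested is made for them only; others in the source may bear on it.

Three compounds have been measured in a functional assay with platelet-activating factor receptor (Cavia porcellus) as the target; a higher number here means that more compound is needed for the effect, a lower number that less compound is needed:

Compound 1 `COc1ccc(C(=C/C=C/C(=O)NCCCCc2cccnc2)c2ccc(OC)c(OC)c2)cc1OC` gives 0.54 mg/kg.
Compound 2 `CC/C(=C\C=C\C(=O)N[C@H](C)CCCc1cccnc1)c1ccc(OC)cc1` gives 0.68 mg/kg.
Compound 3 `O=C(/C=C/C=C(c1ccc(Cl)cc1)c1ccc(Cl)cc1)NCCCCc1cccnc1` gives 0.18 mg/kg.

Among these three numbers compound 1 stands second highest. Its nearest neighbour is compound 2, whose number lies within the usual scatter of that of compound 1, so nothing can be said about which of the two needs more compound. Compound 3 gives the lowest number of the three, and its gap to compound 1 lies beyond the scatter.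

The next compound, compound 4 `COc1ccc(C(=C/C=C/C(=O)N[C@H](C)CCCc2cccnc2)c2ccc(OC)c(OC)c2)cc1OC`, differs from compound 1 by methyl in place of hydrogen on a saturated chain carbon bound to an amide-type nitrogen and a saturated chain carbon. For the measured compounds named here, no measured pair shows this change on its own; compounds 1 and 2 differ in more than one place, and their numbers show only that both lie close together. On that basis the step of a 1.1-fold lower number from compound 1 to compound 4 (0.03 log units; within the scatter) is expected to stay within the scatter, with no clear direction. Compound 4 is therefore estimated to give 0.5 mg/kg in this assay, with a likely range from 0.2 mg/kg to 1.3 mg/kg.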

Compound 4, dose for 50% inhibition: 0.14 mg/kg
For compound 4 the middle estimate is 3.6-fold (0.55 log units) above the measured one; measured number outside the range, below it.
By their numbers in this assay, from the lowest: compounds 4 and 3 (each within the scatter of the next); then compounds 1 and 2 (each within the scatter of the next).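

In this assay, compounds 1 and 4 form the only pair shown that differs in this one place, and the change gives a 3.9-fold lower number from compound 1 to compound 4 (0.59 log units; beyond the scatter). This shows that replacing hydrogen with methyl on this saturated chain carbon, bound to an amide-type nitrogen and a saturated chain carbon, can by itself shift the number beyond the scatter, towards less compound being needed. No evidence is available on what lies behind this step.

Compound 2 also carries this methyl and compound 3 lacks it, but neither has a partner differing only here, so the step is known only on the core of compound 1. The compounds shown also leave open how an ethyl group or a longer chain on this carbon, or the opposite configuration of the methyl-bearing carbon, would read in this assay.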